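Replacing the dimethoxyphenyl of a bromoacrylamide with tolyl

This account rests on a few compounds, and the source may have more. Where it says the series, first, only, none or still open, it means among the compounds named here.

Compounds measured so far:
compound 1 `COc1ccc(-c2nn3cc(-c4cccc(N)c4)nc3s2)cc1OC`, 16000 nM
compound 2 `C=C(Br)C(=O)Nc1cccc(-c2cn3nc(-c4ccc(OC)c(OC)c4)sc3n2)c1`, 42 nM
compound 3 `COc1cccc(-c2nn3cc(-c4cccc(N)c4)nc3s2)c1`, > 250000 nM

In a functional assay on L1210 cells (Mus musculus) for inhibition, read by cell counting, with a stated time of 2 days (a lower number here means a stronger inhibitor, a higher number a weaker inhibitor), compound 2 holds the lowest of the two numbers given; its nearest neighbour is compound 1, and a 380-fold lower number from compound 1 to compound 2 (2.58 log units; beyond the scatter). Compound 3 gives > 250000 nM, which is a limit of the assay rather than a number. That limit nonetheless shows that an at least 15-fold higher number from compound 1 to compound 3 (1.19 log units; beyond the scatter).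

Compound 4 `C=C(Br)C(=O)Nc1cccc(-c2cn3nc(-c4ccc(C)cc4)sc3n2)c1` differs from compound 2 in one place: 4-methylphenyl in place of 3,4-dimethoxyphenyl on an aromatic carbon. The step from compound 1 to compound 3 bears on this change, since it too strips a methoxy from that ring, and it was large and weakening. The bromoacrylamide that drives the step from compound 1 to compound 2 is kept. A weakening step is therefore expected, a 31-fold higher number from compound 2 to compound 4 (1.49 log units; beyond the scatter), and compound 4 is estimated at 1300 nM, within a range of 150 nM to 12000 nM.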

Compound 4, half-maximal inhibitory concentration: 920 nM
The estimate for compound 4 lay 1.4-fold (0.15 log units) above the measured number; measured number inside the range.
By their numbers in this assay, from the lowest: compound 2; then compound 4; then compound 1. At a limit, above all of these: compound 3.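

With the (1-bromoethenyl)carbonyl group in place, the choice of aromatic ring at this position still counts in this assay: there is a 22-fold higher number from compound 2 to compound 4 (1.34 log units; beyond the scatter). The acrylamide therefore does not override the ring change. Compound 3 stands at a limit of the assay, and the earlier step that removed a methoxy thus has no fixed size to set against this one: the limit of > 250000 nM in this assay, at which 1 of the 4 values shown sits.

The compounds shown leave open whether losing the methoxy groups or gaining the methyl matters more, as both change together. From the compounds shown here alone, how a 4-methoxyphenyl or 4-chlorophenyl ring would fare here also remains open.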